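The compounds below may be only part of what the source reports. "The series", "measured", "known", "first", "only" and "open" are said of these compounds alone.

Compound 1 `Cc1cccc(-n2cc(COC(=O)c3cc4ccccc4[nH]3)nn2)c1C` gives 17100 nM in a functional assay on MCF7 cells (Homo sapiens) for cytotoxicity, read by MTT assay, with a stated time of 48 h; on this read-out lower numbers stand for stronger inhibition and higher numbers for weaker inhibition.
Compound 2 `COc1ccc(-n2cc(COC(=O)c3cc4ccccc4n3Cc3cn(-c4ccc(OC)cc4)nn3)nn2)cc1` gives 100000 nM in this assay.
Compound 3 `Cc1cccc(-n2cc(COC(=O)c3cc4ccccc4n3Cc3cn(-c4cccc(C)c4C)nn3)nn2)c1C` sits at a limit, > 200000 nM in this assay.

Compound 1 stands lowest of the two numbers read in this assay; compound 2 sits a gap above it that lies beyond the scatter. Compound 3 reaches only (the limit of > 200000 nM in this assay, at which 1 of the 3 values shown sits).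

Compound 4 `COc1ccc(-n2cc(COC(=O)c3cc4ccccc4[nH]3)nn2)cc1` keeps the core of compound 1 and differs in one place: 4-methoxyphenyl in place of 2,3-dimethylphenyl on an aromatic nitrogen. Going by the values given here, no measured pair covers this exchange. On the heavier core, compound 2 with the same incoming group gives a number where compound 3 with the same outgoing group gives only a limit. The expected step from compound 1 to compound 4 in this assay is a 1.4-fold lower number from compound 1 to compound 4 (0.15 log units; within the scatter), a small move toward lower numbers, within or close to the scatter. The estimate for compound 4 is 12000 nM, between 4000 nM and 40000 nM.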

Compound 4, half-maximal inhibitory concentration: 16200 nM
Compound 4: the middle estimate sits 1.4-fold (0.13 log units) below what was measured; the measured number falls inside the stated range.
By their numbers in this assay, from the lowest: compounds 4 and 1 (each within the scatter of the next); then compound 2. At a limit, above all of these: compound 3.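

The exchange of 2,3-dimethylphenyl for 4-methoxyphenyl on the aromatic nitrogen gives a 1.1-fold lower number from compound 1 to compound 4 (0.02 log units; within the scatter) in this assay on the shared core. Going by these compounds alone, this direct pair, which the earlier compounds did not offer, shows that the number holds when this position gains a methoxy oxygen and loses both methyl groups. Nothing measured here explains why the two groups read alike.

From the compounds shown here alone, whether a smaller group at this nitrogen, such as a methyl or a benzyl, would move the number stays open. So does the effect of a phenyl ring bearing an amine or a carboxylic acid.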